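Tetramethyl core series: replacing the hydroxyalkyl amide with a pyrazole

The source may report more compounds than this note shows. Statements on the series, on what has been measured and on what is new or still open speak of the compounds shown alone.

Within the data shown here, compound 2 `CC1(C)Cc2c(sc(NC(=O)[C@H](O)C(C)(C)C)c2C(N)=O)C(C)(C)O1` is the weaker of the two measured members: in an assay on cells for positive allosteric modulation of Cystic fibrosis transmembrane conductance regulator variant G551D (Homo sapiens), with stated times of 10 min and 2 min, in the presence of a further agent that is not named here (on this read-out higher numbers stand for an effect only at larger amounts of compound and lower numbers for an effect already at smaller amounts), compound 2 gives 7780 nM, whereas compound 1 `CC1Cc2c(sc(NC(=O)c3ccccc3O)c2C(N)=O)C(C)O1` gives 236 nM. Among the measured compounds shown here, no single-site step between these two is given, so only the two values themselves are set side by side; the gap between them is beyond the scatter, and compound 1 also carries a different core.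

Compound 3 `Cc1n[nH]c(C(=O)Nc2sc3c(c2C(N)=O)CC(C)(C)OC3(C)C)c1Cl` differs from compound 2 at one place: a group of 7 heavy atoms (4 carbon, 2 nitrogen, 1 chlorine; one five-membered aromatic ring with 2 hetero atoms) in place of a group of 6 heavy atoms (5 carbon, 1 oxygen; no ring), on a carbonyl carbon. The group that enters, with its five-membered aromatic ring, brings compound 3 closer in kind to the acyl portion of compound 1, while the core of compound 2 is kept.

On that basis the expected step from compound 2 to compound 3 in this assay, a 9.7-fold lower number from compound 2 to compound 3 (0.99 log units; beyond the scatter), is toward lower numbers and beyond the scatter. Compound 3 is estimated at 800 nM, with a range from 150 nM to 4000 nM.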

Compound 3, half-maximal effective concentration: 199 nM
Estimate against measurement, compound 3: 4.0-fold (0.60 log units) above; measured number inside the range.
By their numbers in this assay, from the lowest: compounds 3 and 1 (each within the scatter of the next); then compound 2.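

With the core held fixed, the place on the carbonyl carbon carries a large change in this assay: a five-membered aromatic ring with 2 hetero atoms in place of 1-hydroxy-2,2-dimethylpropyl gives a 39-fold lower number from compound 2 to compound 3 (1.59 log units; beyond the scatter). The leaving and entering groups have the same counts of hydrogen-bond donors and acceptors, so the step does not go with a change in those counts, and the defined stereocentre of the leaving group is gone in compound 3. No measurement shown bears on the reason for this step.

Which part of the entering group goes with the step remains open, for instance whether bromine or a methoxy group could stand in place of the chlorine. On these data alone, the contribution of the core also remains open, since compound 1 and compound 3 differ in more than one place.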